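Working notes: from compound 3 to compound 4

The source may hold more compounds than are shown below. What is called first, only, known or untested is meant among the compounds shown, and "the series" means these compounds.

Measured so far in a functional assay on WiDr cells (Homo sapiens) for inhibition, read by sulforhodamine B assay, with a stated time of 48 h; on this read-out lower numbers stand for stronger inhibition of growth and higher numbers for weaker inhibition of growth:
compound 1 `O=C(/C(=C/c1ccccc1)CCl)c1ccccc1` gives 18000 nM
compound 2 `O=C(/C(=C/c1ccc(Cl)cc1)CCl)c1ccccc1` gives 19000 nM
compound 3 `CC(=O)OC/C(=C\C1CCCCC1)C(=O)c1ccccc1` gives 21000 nM

Compound 3 sits at the top of the three numbers, but its gaps to compound 2 and to compound 1 are both within the scatter, so no order among the three can be claimed from this assay. Going by the values given here, the single step between compounds that differ in one place is a 1.1-fold higher number from compound 1 to compound 2 (0.02 log units; within the scatter), flat within the scatter.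

Compound 4 `CC(=O)OC/C(=C\c1ccc(F)cc1)C(=O)c1ccccc1` differs from compound 3 by 4-fluorophenyl in place of cyclohexyl on a double-bonded chain carbon bound to a double-bonded chain carbon. Among the compounds with values here, no measured step exchanges a saturated ring for an aromatic one, so this change has no direct precedent here; the only step on record, a chloro on an aromatic carbon, left the number unchanged within the scatter. Nothing in the data points to a shift beyond the scatter, so the expected step of a 1.1-fold lower number from compound 3 to compound 4 (0.04 log units; within the scatter) is taken as small. Compound 4 is therefore estimated to give 19000 nM in this assay, with a range of 8000 nM to 45000 nM.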

Compound 4, concentration for 50% growth inhibition: 13000 nM
Compound 4: middle estimate off by 1.5-fold (0.16 log units), on the high side; the range from low to high includes it.
By their numbers in this assay, from the lowest: compounds 4, 1, 2 and 3 (each within the scatter of the next).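

In this assay, the exchange of cyclohexyl for 4-fluorophenyl on a double-bonded chain carbon bound to a double-bonded chain carbon gives a 1.6-fold lower number from compound 3 to compound 4 (0.21 log units; within the scatter) and so stays within the scatter. Going by these compounds alone, this is the first step to exchange a saturated ring for an aromatic one at this place, whereas the earlier step only added chloro on an aromatic carbon; on the core of compound 3, either ring is tolerated with no separable difference in growth inhibition. No measurement available here offers an explanation for this result.

On the core of compound 3, an unsubstituted phenyl would be needed to separate the ring exchange from the fluorine it brings. As far as these compounds go, whether an open-chain group such as n-hexyl, or a ring carrying an amine or a carboxylic acid, would move the number beyond the scatter remains open.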